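A Thiophene Swap Tested Against Liver Cell Tolerance

The source may report more compounds than this note shows. Statements on the series, on what has been measured and on what is new or still open speak of the compounds shown alone.

Compound 1 `COc1ccc(-c2cc(Cl)cn3c([N+](=O)[O-])c(CS(=O)(=O)c4ccccc4)nc23)cc1` is the starting point. In an ADME assay on HepG2 cells (Homo sapiens) for cytotoxicity, read by MTT assay, with a stated time of 72 h (a higher number here means that more compound is tolerated, a lower number that less compound is tolerated), compound 1 gives only a limit of the assay, > 3900 nM. Compound 2 `O=[N+]([O-])c1c(CS(=O)(=O)c2ccccc2)nc2c(-c3cccc(CO)c3)cc(Cl)cn12` carries 3-(hydroxymethyl)phenyl in place of 4-methoxyphenyl on an aromatic carbon. In this assay compound 2 also reaches only a limit, > 25000 nM. Compound 3 `O=[N+]([O-])c1c(CS(=O)(=O)c2ccccc2)nc2c(-c3ccc(C(F)(F)F)cc3)cc(Cl)cn12` has trifluoromethyl in place of methoxy on an aromatic carbon. In this assay compound 3 likewise sits at a limit, > 3900 nM. All three values are limits, so the steps a step that the two limits leave unreadable from compound 1 to compound 2, a step that the two limits leave unreadable from compound 1 to compound 3 and a step that the two limits leave unreadable from compound 2 to compound 3 cannot be sized; two values rest at the limit of > 3900 nM in this assay, at which 2 of the 3 values shown sit, and one at the limit of > 25000 nM in this assay, at which 1 of the 3 values shown sits.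

Compound 4 `O=[N+]([O-])c1c(CS(=O)(=O)c2ccccc2)nc2c(-c3cccs3)cc(Cl)cn12` is not yet measured. It differs from compound 1 in one place: thiophen-2-yl in place of 4-methoxyphenyl on an aromatic carbon. Among the measured compounds shown here, none of the measured steps involves a thiophen-2-yl, and all of them are unreadable in size; they show only that compound 1 and its two neighbours are tolerated up to the limits tested. Compound 4 is therefore expected to show a step that the limit leaves unreadable from compound 1 to compound 4, no larger than the scatter. The estimate for compound 4 is 10000 nM, with a range from 3900 nM to 50000 nM, and a limit rather than a number is the most likely report.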

Compound 4, half-maximal cytotoxic concentration: > 3900 nM
Compound 4 ended at the assay's limit; the forecaster's own chance of this, stated with the estimate: 85%; the middle value is on the limit's open side.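

In this assay compound 4 gives only a limit of the assay, > 3900 nM. Among the compounds shown here, compound 1, compound 2 and compound 3 also rest at limits, so no step to compound 4 can be read. The compounds shown leave open how much of each compound the cells tolerate, and whether thiophen-2-yl differs from the other groups at all.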